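The source may report more compounds than this note shows. Statements on the series, on what has been measured and on what is new or still open speak of the compounds shown alone.

Series notes. Compound 1 `CCCCNC(=N)NC(=N)Nc1ccc(Cl)cc1` stands lowest of the two numbers measured: in a physicochemical assay for lipophilicity, in phosphate buffer, measured as octanol-water partition, at pH 11.5 (on this read-out higher numbers stand for higher lipophilicity and lower numbers for lower lipophilicity), compound 1 gives 3.13, while compound 2 `CCCCCCCCCCNC(=N)NC(=N)Nc1ccccc1` gives 5.43, a gap that lies beyond the usual scatter. Compound 3 `CCCCOC(=N)NC(=N)Nc1ccc(Cl)cc1` is not yet measured; it differs from compound 1 by butoxy in place of butylamino on a carbon with a double bond to nitrogen. Within the data shown here, no measured pair in the set carries this change, so the size of the step rests on expectation alone: a small rise, or nothing beyond the scatter, with the step of a number 0.17 log units higher from compound 1 to compound 3 (within the scatter) expected. For compound 3 the estimate in this assay is 3.3, in the range 2.7 to 3.9.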

Compound 3, partition coefficient: 3.32
Compound 3: the middle estimate sits 0.02 log units below what was measured; the measured number falls inside the stated range.
By their numbers in this assay, from the lowest: compounds 1 and 3 (each within the scatter of the next); then compound 2.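

In this assay, among these compounds, there is a number 0.19 log units higher from compound 1 to compound 3 (within the scatter) for butoxy in place of butylamino on a carbon with a double bond to nitrogen, the first reading of this change at this position. The swap removes a hydrogen-bond donor and brings in a hydrogen-bond acceptor, yet for this pair the read-out stays within the scatter. Nothing measured here accounts for this result.

Going by these compounds, whether the same change holds with a longer chain, such as decyloxy, remains open. So does what a dimethylamino or butylthio group would give at this place.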